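Chalcone-type dimethoxyphenyl series: antiproliferative readings on lung cells

This account rests on a few compounds, and the source may have more. Where it says the series, first, only, none or still open, it means among the compounds named here.

Measured so far:
compound 1 `COc1ccc(-c2cc(C(=O)/C=C/c3ccccc3)nc3cc(-c4ccccc4)nn23)cc1OC` — 18600 nM
compound 2 `COc1ccc(-c2cc(C(=O)/C=C/c3ccc(Cl)cc3)nc3cc(-c4ccccc4)nn23)cc1OC` — 22000 nM
compound 3 `COc1ccc(-c2cc(/C=C/C(=O)c3ccccc3)nc3cc(-c4ccccc4)nn23)cc1OC` — 10700 nM

All three were read in a functional assay on A549 cells (Homo sapiens) for antiproliferative activity, read by MTT assay, with a stated time of 24 h; a lower number here means a stronger inhibitor, a higher number a weaker inhibitor. Compound 1 gives 18600 nM in this assay, compound 2 gives 22000 nM, and compound 3 gives 10700 nM. The change from compound 1 to compound 2 is chloro in place of hydrogen on an aromatic carbon; the step it made was a 1.2-fold higher number from compound 1 to compound 2 (0.07 log units; within the scatter). Compound 3 carries a rearranged linker relative to compound 1, the difference being (2-benzoylethenyl in place of (2-phenylethenyl)carbonyl on an aromatic carbon); the step there was a 1.7-fold lower number from compound 1 to compound 3 (0.24 log units; within the scatter), and from the chlorinated analogue the step was a 2.1-fold lower number from compound 2 to compound 3 (0.31 log units; beyond the scatter). Compound 3 thus stands with the lowest number of the three, though only the gap to compound 2 is beyond the scatter.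

Compound 4 `COc1ccc(-c2cc(/C=C/C(=O)c3ccc(Cl)cc3)nc3cc(-c4ccccc4)nn23)cc1OC` has not yet been measured. It differs from compound 3 by chloro in place of hydrogen on an aromatic carbon, the same change as that between compound 1 and compound 2, set on the same kind of place. Among the measured compounds shown here, with only one prior instance of this change, which stayed within the scatter, the step from compound 3 to compound 4 is expected to be similarly small, about a 1.2-fold higher number from compound 3 to compound 4 (0.07 log units; within the scatter), resting on the earlier 1.2-fold higher number from compound 1 to compound 2 (0.07 log units; within the scatter). Compound 4 is therefore estimated at 12500 nM in this assay, with an expected range from 6500 nM to 25000 nM.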

Compound 4, half-maximal inhibitory concentration: 15400 nM
For compound 4 the middle estimate is 1.2-fold (0.09 log units) below the measured one, and the stated range covers the measured number.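

In this assay, chloro in place of hydrogen on the core of compound 3 gives a 1.4-fold higher number from compound 3 to compound 4 (0.16 log units; within the scatter), and set beside the same change on the core of compound 1 the two steps agree: the same change on two cores in this assay, a 1.2-fold higher number (0.07 log units; within the scatter) from compound 1 to compound 2 and a 1.4-fold higher number (0.16 log units; within the scatter) from compound 3 to compound 4, 1.2-fold (0.09 log units) apart, within the scatter of two such steps

With chloro present on both sides, the rearranged linker also stays small, with a 1.4-fold lower number from compound 2 to compound 4 (0.15 log units; within the scatter), and the two changes taken together give a 1.2-fold lower number from compound 1 to compound 4 (0.08 log units; within the scatter). Among the compounds shown here, neither chloro step is beyond the scatter, so the pair shows only that a small step carries over between these two cores; it does not show that chloro shifts the reading at all, and it says nothing about a third core or another place on the ring.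

Open, from the compounds shown here alone, is whether a larger or charged group at the same place, such as an amine or a carboxylic acid, would move the number beyond the scatter where chloro does not. Going by these compounds, the dimethoxyphenyl and phenyl groups also stay the same across all four compounds, so the response in this assay to replacing either of them, for instance with a longer chain, remains unknown.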